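Compound 3: ester oxygen inserted on the pentyl series

The compounds below may be only part of what the source reports. "The series", "measured", "known", "first", "only" and "open" are said of these compounds alone.

Measured so far in an assay on isolated protein for displacement of a labelled ligand from thyroid hormone receptor alpha (Homo sapiens), read by fluorescence polarization; on this read-out higher numbers stand for weaker inhibition and lower numbers for stronger inhibition:
compound 1 `C=CC(=O)c1ccc(CCCCC)cc1`, 60900 nM
compound 2 `C=CC(=O)c1ccc(CCCCCCC)cc1`, 23000 nM

Among the compounds with values here, compound 1 stands at the highest of the two numbers in this assay; the only step measured, a 2.6-fold lower number from compound 1 to compound 2 (0.42 log units; beyond the scatter), lengthens the saturated chain and leaves the vinylcarbonyl group untouched. Compound 3 `C=CC(=O)Oc1ccc(CCCCC)cc1` differs from compound 1 by (vinylcarbonyl)oxy in place of vinylcarbonyl on an aromatic carbon, so the ring-bound group itself is altered while the pentyl chain is kept. Within the data shown here, no measured step covers a change of this kind: the step from compound 1 to compound 2 concerns the chain only and does not bear on the group attached to the ring. With nothing in the series to anchor the direction, the expected step of a 1.0-fold lower number from compound 1 to compound 3 (0.01 log units; within the scatter) is none beyond the scatter, with wide uncertainty either way. Compound 3 is therefore estimated at 60000 nM, with a range from 15000 nM to 240000 nM.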

Compound 3, half-maximal inhibitory concentration: > 100000 nM
Compound 3: no number, only a limit (the forecaster's own chance of this, stated with the estimate: 25%); at least 1.6-fold (0.22 log units) between middle value and limit.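

In this assay, compound 3 gives > 100000 nM, which is a limit of the assay and not a number. Within the data shown here, with the pentyl chain kept, (vinylcarbonyl)oxy in place of vinylcarbonyl gives an at least 1.6-fold higher number from compound 1 to compound 3 (0.21 log units; that floor lies within the scatter), the first reading at the ring-bound group, since the earlier step concerned the chain only. This position therefore shows no settled separation of compound 3 from compound 1, and the reading rests on a single value of that kind: the limit of > 100000 nM in this assay, at which 1 of the 3 values shown sits.

Still open, as far as these compounds go, is whether the same change on the longer chain of compound 2 would give a number rather than a limit. Also open, from the compounds shown here alone, is how an amide nitrogen in place of the inserted oxygen, or a saturated propanoyl group in place of vinylcarbonyl, would read in this assay.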